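A difluoromethyl group at the position of a methyl

A few compounds are considered here, and "the series" means these few. Any claim that something is new, unique, unknown or untested is made for them only; others in the source may bear on it.

Of the compounds shown here, three have been measured in an assay on isolated protein for inhibition of AP2-associated protein kinase 1 (Homo sapiens), with a stated time of 3 h, in the presence of a further agent that is not named here; a higher number here means a weaker inhibitor, a lower number a stronger inhibitor. Compound 1 `COC(=O)Nc1cc(-c2cc(C)c(OC[C@@](C)(N)CC(C)C)cn2)ccn1` gives 1.7 nM. Compound 2 `Cc1cc(-c2cc(C)c(OC[C@@](C)(N)CC(C)C)cn2)ccn1` gives 19 nM, and compound 3 `CC(=O)Nc1cc(-c2ccc(OC[C@@H](N)CC(C)C)cc2)ccn1` gives 4.6 nM. On these numbers compound 2 stands highest, that is, it is the weakest of the three; compound 3 sits nearer to it, and compound 1 furthest away.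

Going by the values given here, the one measured step that reaches compound 2 is an 11-fold higher number from compound 1 to compound 2 (1.05 log units; beyond the scatter). It shows that the group on this aromatic carbon, the one next to the ring nitrogen, matters a great deal for the number in this assay.

Compound 4 `Cc1cc(-c2ccnc(C(F)F)c2)ncc1OC[C@@](C)(N)CC(C)C` has not been measured. It differs from compound 2 in one place: difluoromethyl in place of methyl on an aromatic carbon. The measured step changed the same position, but with a very different kind of group, so it tells only that this position is sensitive, not which way a difluoromethyl will move the number. A modest change is therefore the most that can be expected, with the direction uncertain, and the estimate is placed a little below compound 2 while allowing for no change beyond the scatter.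

Compound 4 is expected to give 12 nM in this assay, within a range from 4 nM to 40 nM. This estimate corresponds to an expected step of a 1.6-fold lower number from compound 2 to compound 4 (0.20 log units; within the scatter).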

Compound 4, half-maximal inhibitory concentration: 1.4 nM
Compound 4: the middle estimate sits 8.6-fold (0.93 log units) above what was measured; the whole stated range lies above it.
By their numbers in this assay, from the lowest: compounds 4 and 1 (each within the scatter of the next); then compound 3; then compound 2.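

In this assay, this position next to the ring nitrogen responds strongly even to a change from one small group to another: difluoromethyl in place of methyl gives a 14-fold lower number from compound 2 to compound 4 (1.13 log units; beyond the scatter) on an otherwise unchanged compound. The earlier step showed only that replacing (methoxycarbonyl)amino with methyl raises the number, which could have meant that the low number depends on (methoxycarbonyl)amino itself, but a 1.2-fold lower number from compound 1 to compound 4 (0.08 log units; within the scatter) stays within the scatter, so difluoromethyl serves here as well as that group does. Among the three groups seen at this position on this core, methyl is therefore the one that stands apart, with the other two giving numbers that cannot be told apart in this assay.

No measurement shown here explains why two fluorine atoms on this carbon have so large an effect. On these data alone, it remains open whether a single fluorine, as in fluoromethyl, captures part of the step, whether a third, as in trifluoromethyl, preserves it, and whether a plain ethyl group or an amine at this position would behave more like methyl or like difluoromethyl.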